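Replacing a (2-chlorophenyl)sulfanyl group with 4-methyl-1H-imidazol-1-yl

This account rests on a few compounds, and the source may have more. Where it says the series, first, only, none or still open, it means among the compounds named here.

Measured so far in a functional assay for inhibition of sodium/hydrogen exchanger (Oryctolagus cuniculus); on this read-out higher numbers stand for weaker inhibition and lower numbers for stronger inhibition:
compound 1 `Cc1cc(Sc2ccccc2Cl)c(S(C)(=O)=O)cc1C(=O)N=C(N)N` gives 14 nM
compound 2 `CCc1cc(OC)c(S(C)(=O)=O)cc1C(=O)N=C(N)N` gives 30 nM
compound 3 `Cc1c(C(=O)N=C(N)N)cc(S(C)(=O)=O)c(-n2ccnc2)c1C` gives 290 nM

Compound 1 has the lowest number of the three, with compound 2 the nearest and compound 3 the furthest, both beyond the scatter. Compound 4 `Cc1cn(-c2cc(C)c(C(=O)N=C(N)N)cc2S(C)(=O)=O)cn1` has not yet been measured. It differs from compound 1 in one place: 4-methyl-1H-imidazol-1-yl in place of (2-chlorophenyl)sulfanyl on an aromatic carbon. For the measured compounds named here, no measured pair shows this exact change on a shared core, so its size cannot be read from a step. Going by the values given here, compound 3, the only measured compound bearing an imidazol-1-yl group, gives 290 nM in this assay, which suggests a weaker inhibitor. Compound 4 is therefore expected at about 150 nM, between 50 nM and 500 nM, an estimated step of an 11-fold higher number from compound 1 to compound 4 (1.03 log units; beyond the scatter).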

Compound 4, half-maximal inhibitory concentration: 28 nM
Beside the measured number, compound 4's estimate is 5.4-fold (0.73 log units) above it; measured number outside the range, below it.
By their numbers in this assay, from the lowest: compounds 1, 4 and 2 (each within the scatter of the next, the first and the last beyond it); then compound 3.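

In this assay, putting 4-methyl-1H-imidazol-1-yl in place of (2-chlorophenyl)sulfanyl gives a 2.0-fold higher number from compound 1 to compound 4 (0.30 log units; within the scatter). This position, ortho to a methylsulfonyl group, therefore tolerates a five-membered aromatic ring with 2 hetero atoms instead of a six-membered aromatic ring of carbon only, with no change beyond the scatter. Nothing available explains why the two groups read alike. Still open, going by these compounds, is what a simple amine such as dimethylamino or a carboxylic acid would do at this position. Also open, on these data alone, is whether the methyl on the imidazole ring contributes, which the unsubstituted imidazol-1-yl group on the core of compound 4 would test.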